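Benzyl for isobutyl on a second carbamate core

The compounds below may be only part of what the source reports. "The series", "measured", "known", "first", "only" and "open" are said of these compounds alone.

Measured so far:
Compound 1, `Cc1c(Oc2ccc(/C=C3\SC(=O)NC3=O)cc2)ncnc1OC1CCN(C(=O)OCC(C)C)CC1`: 75.1 nM
Compound 2, `Cc1c(Oc2ccc(/C=C3\SC(=O)NC3=O)cc2)ncnc1OC1CCN(C(=O)OCc2ccccc2)CC1`: 805 nM
Compound 3, `CC(C)COC(=O)N1CCC(Oc2cc(Oc3cccc(/C=C4\SC(=O)NC4=O)c3)ncn2)CC1`: 720 nM

All three compounds were tested in a functional assay on CHO-K1 cells for agonist activity at Glucose-dependent insulinotropic receptor (Homo sapiens), read by cAMP accumulation and immunoassay, with a stated time of 1 h; on this read-out lower numbers stand for an effect already at smaller amounts and higher numbers for an effect only at larger amounts of compound. Compound 1 and compound 2 share one core, and compound 3 carries a different core; the difference between the two cores is not broken down here. Compound 2 and compound 3 sit close together, while compound 1 sits apart from both.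

Within the first core, a single change is known: phenyl in place of isopropyl on a saturated chain carbon bound to an oxygen next to a carbonyl group. This gave an 11-fold higher number from compound 1 to compound 2 (1.03 log units; beyond the scatter). In this assay compound 2 therefore needs a much larger amount than compound 1 to reach the same effect.

Compound 4, `O=C1NC(=O)/C(=C/c2cccc(Oc3cc(OC4CCN(C(=O)OCc5ccccc5)CC4)ncn3)c2)S1`, has not yet been measured. It is made from compound 3 by the same change, (phenyl in place of isopropyl on a saturated chain carbon bound to an oxygen next to a carbonyl group), and the change sits at exactly the same place in both pairs. The only known example of this change is the step from compound 1 to compound 2; whether the second core responds alike is not shown by any measured pair. Starting from compound 3, the expected step is an 8.3-fold higher number from compound 3 to compound 4 (0.92 log units; beyond the scatter), resting on the size of an 11-fold higher number from compound 1 to compound 2 (1.03 log units; beyond the scatter) and on the position of compound 3 at 720 nM. In this assay compound 4 is therefore expected to give about 6000 nM, most likely between 2000 nM and 20000 nM, with a modest chance that only a limit is reported.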

Compound 4, half-maximal effective concentration: 153 nM
Compound 4: middle estimate off by 39-fold (1.59 log units), on the high side; the whole stated range lies above it.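

On the core of compound 3, putting benzyl in place of isobutyl gave a 4.7-fold lower number from compound 3 to compound 4 (0.67 log units; beyond the scatter), a step in the opposite direction to the one seen for the same change on the core of compound 1. In this assay, the result of this change therefore depends on the core that carries it, and the size or even the direction of a step measured on one core cannot simply be transferred to the other: the same change on two cores in this assay, an 11-fold higher number (1.03 log units; beyond the scatter) from compound 1 to compound 2 and a 4.7-fold lower number (0.67 log units; beyond the scatter) from compound 3 to compound 4, 50-fold (1.70 log units) apart, beyond the scatter of two such steps

Among these compounds, this shows only that the two cores respond differently to this one swap; it does not show which feature of the cores is responsible or how the change would behave on any third core, and a single pair per core gives no general rule for the series.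

From the compounds shown here alone, it remains open whether other groups in place of isobutyl, such as a longer chain ending in phenyl, a cyclohexyl ring or a chain carrying an amine, would also behave differently on the two cores. Going by these compounds, it is equally open which part of the difference between the two cores reverses the direction of the step, and whether benzyl would still be favoured on the core of compound 3 against such groups.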